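KIF15 series: oxindole core, aryl substituent swap at position

A few compounds are considered here, and "the series" means these few. Any claim that something is new, unique, unknown or untested is made for them only; others in the source may bear on it.

Measured compounds:
compound 1 `O=C1Nc2ccc(C(=O)c3ccco3)cc2/C1=C/c1cc(Br)c(O)c(Br)c1`: 65%
compound 2 `O=C1Nc2ccc(C(=O)c3ccco3)cc2/C1=C/c1ccc(Br)c(O)c1`: -5.6%
compound 3 `O=C1Nc2ccc(C(=O)N3CCCC3)cc2/C1=C/c1cc(Cl)c(O)c(Cl)c1`: -10%

In an assay on HeLa cells for inhibition of Kinesin-like protein KIF15 (Homo sapiens), read by microscopy, with stated times of 2 s and 20 s, tested at 750 nM (on this read-out higher numbers stand for more inhibition at the one concentration tested (going by the name of the read-out) and lower numbers for less inhibition), compound 3 gives -10%, the lowest of the three numbers; its gap to compound 2 is within the scatter, while compound 1 stands well above it, beyond the scatter. For the measured compounds named here, the one measured step, a number 70.6 percentage points lower from compound 1 to compound 2 (beyond the scatter), concerns the phenol ring and not the position changed here, so it gives no direct guidance. Compound 1 and compound 3 differ in two places at once, so their values only show that the pair with the furanyl carbonyl and dibromo phenol sits high and the pair with the pyrrolidinyl carbonyl and dichloro phenol sits low.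

Compound 4 `O=C1Nc2ccc(-c3ccccn3)cc2/C1=C/c1cc(Cl)c(O)c(Cl)c1` carries the change (pyridin-2-yl in place of (pyrrolidin-1-yl)carbonyl on an aromatic carbon). Going by the values given here, no measured step bears on this position, so no direction is expected with confidence; a modest rise beyond the scatter is treated as possible but uncertain. Compound 4 is estimated at 15%, range -15% to 50%, which means an expected step of a number 25 percentage points higher from compound 3 to compound 4 (beyond the scatter).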

Compound 4, a percentage reported as inhibition, at one concentration (the size of the read-out at that concentration, not a potency): 7.3%
Estimate against measurement, compound 4: 7.7 percentage points above, and the stated range covers the measured number.
By their numbers in this assay, from the lowest: compounds 3 and 2 (each within the scatter of the next); then compound 4; then compound 1.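

In this assay, for the compounds shown here, the step of a number 17.3 percentage points higher from compound 3 to compound 4 (beyond the scatter) gives the first reading at this position, on an aromatic carbon of the shared core, with the rest of the structure held constant. It shows that the number responds to the group placed here, although modestly, when a directly attached six-membered aromatic ring replaces a five-membered non-aromatic ring attached through a carbonyl. Nothing available explains this step.

The compounds shown leave open whether the nitrogen of pyridin-2-yl matters, which a plain phenyl group at the same place would test, and how a carboxylic acid or an open-chain amine there would read. From the compounds shown here alone, it also remains open whether the same swap gives a similar step when the dibromo-substituted phenol replaces the dichloro-substituted one.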